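Varying the aryl group on the amide side chain

The source may hold more compounds than are shown below. What is called first, only, known or untested is meant among the compounds shown, and "the series" means these compounds.

Compound 1 `CC(C)C[C@H](N)c1cc(C(F)(F)F)ccc1N1CCN(C(=O)COc2ccc3ccccc3c2)CC1`: in an assay on HEK293 cells for displacement of a labelled ligand from Melanocortin receptor 4 (Homo sapiens) (a higher number here means a weaker inhibitor, a lower number a stronger inhibitor), compound 1 gives 2000 nM.
Compound 2 `CC(C)C[C@H](N)c1cc(C(F)(F)F)ccc1N1CCN(C(=O)C(C)Cc2ccc(Cl)c(Cl)c2)CC1`: in this assay compound 2 gives 120 nM; 1600 nM (2 entries).
Compound 3 `COc1ccc(CC(C)C(=O)N2CCN(c3ccc(C(F)(F)F)cc3[C@@H](N)CC(C)C)CC2)cc1F`: in this assay compound 3 gives 200 nM.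

Compound 3 holds the lowest of the two single numbers; compound 1 sits well above it, a 10-fold lower number from compound 1 to compound 3 (1.00 log units; beyond the scatter). Compound 2 offers no firm anchor, since its repeated entries disagree widely, (the several entries of compound 2 in this assay, 120 nM; 1600 nM (2 entries)). Compound 4 `Cc1cc(Cl)ccc1CC(C)C(=O)N1CCN(c2ccc(C(F)(F)F)cc2[C@@H](N)CC(C)C)CC1` keeps the shared core and alters only the ring on the side chain: 4-chloro-2-methylphenyl in place of 3-fluoro-4-methoxyphenyl on a saturated chain carbon, two bonds along the chain from a carbonyl carbon. Among the measured compounds shown here, the one measured step, from compound 1 to compound 3, changed the whole linkage, not merely ring substituents, so it bears only loosely here. The expectation is therefore no shift beyond the scatter, a 1.3-fold higher number from compound 3 to compound 4 (0.10 log units; within the scatter). Compound 4 is estimated at 250 nM, within 70 nM to 900 nM.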

Compound 4, inhibition constant: 38 nM
Estimate against measurement, compound 4: 6.6-fold (0.82 log units) above; the measured number lies below the stated range.
By their numbers in this assay, from the lowest: compound 4; then compound 3; then compound 1.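

Ring substituents alone matter at this position: with the linkage to the carbonyl carbon unchanged, 4-chloro-2-methylphenyl in place of 3-fluoro-4-methoxyphenyl gives a 5.3-fold lower number from compound 3 to compound 4 (0.72 log units; beyond the scatter) in this assay. The wider replacement of ((naphthalen-2-yl)oxy)methyl gives a 53-fold lower number from compound 1 to compound 4 (1.72 log units; beyond the scatter) in the same assay, but that step changes the linkage as well as the ring. Nothing measured here explains the difference between these rings.

As far as these compounds go, the separate contributions of the chlorine and the methyl remain open, since both enter together. So does the outcome with an unsubstituted phenyl or a pyridine ring on this chain.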